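One added group on compound 2

A few compounds are considered here, and "the series" means these few. Any claim that something is new, unique, unknown or untested is made for them only; others in the source may bear on it.

In an ADME assay on the whole organism (plasma) with Homo sapiens as the target (on this read-out lower numbers stand for a shorter-lived compound and higher numbers for a longer-lived compound), compound 2 `COC(=O)c1ccccc1OC(C)=O` gives 0.0533 h. Compound 1 `CC(=O)OCOC(=O)c1ccccc1OC(C)=O` gives 0.03 h, which lies within the scatter of that number. Compound 3 `CC(=O)Oc1ccccc1C(=O)Oc1ccccc1` gives 0.0217 h. That gap, a 2.5-fold lower number from compound 2 to compound 3 (0.39 log units; beyond the scatter), is modest but beyond the scatter.

Compound 4 `CCCC(=O)OCOC(=O)c1ccccc1OC(C)=O` has not yet been measured. It has (propylcarbonyl)oxy in place of hydrogen on a saturated chain carbon bound to an oxygen next to a carbonyl group. The closest guide is compound 1, which carries acetoxy at that same place. The relevant step, a 1.8-fold higher number from compound 1 to compound 2 (0.25 log units; within the scatter), stayed within the scatter. A second step, a 1.4-fold lower number from compound 1 to compound 3 (0.14 log units; within the scatter), also stayed within it, but it swaps the whole acetoxymethyl for phenyl and so bears less directly. Within the data shown here, no measured compound carries (propylcarbonyl)oxy, so the guidance is indirect. In this assay, the expected change is small and, if visible at all, towards a lower number: a 1.8-fold lower number from compound 2 to compound 4 (0.25 log units; within the scatter), within the scatter. Compound 4 is estimated at 0.03 h, with an expected range of 0.014 h to 0.065 h.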

Compound 4, half-life: 0.0167 h
Beside the measured number, compound 4's estimate is 1.8-fold (0.25 log units) above it; measured number inside the range.
By their numbers in this assay, from the lowest: compounds 4, 3, 1 and 2 (each within the scatter of the next, the first and the last beyond it).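

In this assay, (propylcarbonyl)oxy on a saturated chain carbon bound to an oxygen next to a carbonyl group moves the number beyond the scatter relative to hydrogen (a 3.2-fold lower number from compound 2 to compound 4 (0.50 log units; beyond the scatter)), whereas acetoxy at this place had stayed within it. Ethyl in place of hydrogen on a saturated chain carbon bound to a carbonyl carbon, the only difference between the two groups, stays within the scatter (a 1.8-fold lower number from compound 1 to compound 4 (0.25 log units; within the scatter)), so these two groups cannot be told apart here. No measurement shown speaks to the cause of either step.

From the compounds shown here alone, whether a longer chain on that carbonyl carbon would take the number further in the same direction remains open. So does what an amine or a carboxylic acid at this place would do.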